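Triazolylmethyl for carboxy on a double-bonded ring carbon

This account rests on a few compounds, and the source may have more. Where it says the series, first, only, none or still open, it means among the compounds named here.

Measured compounds:
Compound 1 `CC(=O)OC/C1=C/C[C@](C)(CCC=C(C)C)/C=C/[C@@H](OC(=O)C=C(C)C)[C@](C)(OC(C)=O)/C=C/C1=O`: 3990 nM
Compound 2 `CC(C)=CCC[C@]1(C)/C=C/[C@@H](OC(=O)C=C(C)C)[C@](C)(O)/C=C/C(=O)/C(C(=O)O)=C\C1`: 16100 nM

Of the compounds shown here, two have been measured in a functional assay on MCF7 cells (Homo sapiens) for antiproliferative activity, read by MTT assay, with a stated time of 48 h; a lower number here means a stronger inhibitor, a higher number a weaker inhibitor. Compound 1 `CC(=O)OC/C1=C/C[C@](C)(CCC=C(C)C)/C=C/[C@@H](OC(=O)C=C(C)C)[C@](C)(OC(C)=O)/C=C/C1=O` gives 3990 nM, and compound 2 `CC(C)=CCC[C@]1(C)/C=C/[C@@H](OC(=O)C=C(C)C)[C@](C)(O)/C=C/C(=O)/C(C(=O)O)=C\C1` gives 16100 nM. Compound 2 thus stands at the higher of the two numbers, and its gap to compound 1 lies beyond the scatter of this kind of measurement.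

Compound 3 `CC(C)=CCC[C@]1(C)/C=C/[C@@H](OC(=O)C=C(C)C)[C@](C)(O)/C=C/C(=O)/C(Cn2cc(CO)nn2)=C\C1` is the next compound. It differs from compound 2 in one place: (4-(hydroxymethyl)-1H-1,2,3-triazol-1-yl)methyl in place of carboxy on a double-bonded ring carbon. The carboxy group sits on a double-bonded ring carbon of the non-aromatic ring of carbon only, and in compound 3 that position carries the (4-(hydroxymethyl)-1H-1,2,3-triazol-1-yl)methyl group instead.

Going by the values given here, no measured pair in this set follows the same change, so the step to compound 3 cannot be read from the two values shown. The expectation is a modest step from compound 2 to compound 3 toward a lower number, a 2.0-fold lower number from compound 2 to compound 3 (0.30 log units; within the scatter), though one that could just as well fall within the scatter. Compound 3 is estimated at 8000 nM in this assay, with a range from 2500 nM to 25000 nM.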

Compound 3, half-maximal inhibitory concentration: 2930 nM
For compound 3 the middle estimate is 2.7-fold (0.44 log units) above the measured one, and the stated range covers the measured number.
By their numbers in this assay, from the lowest: compounds 3 and 1 (each within the scatter of the next); then compound 2.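

In this assay, this double-bonded ring carbon accepts a much bigger group than carboxy: the change to (4-(hydroxymethyl)-1H-1,2,3-triazol-1-yl)methyl, with 8 heavy atoms in place of 3, gives a 5.5-fold lower number from compound 2 to compound 3 (0.74 log units; beyond the scatter) and so moves the number in the stronger direction. Going by these compounds alone, the earlier compounds offered no change in one place at this position, so this is the first direct reading of it. It shows that a carboxy group on this carbon is not required for activity in this assay, and that a five-membered aromatic ring with 3 hetero atoms, held through a methylene link, is tolerated there. Nothing measured here explains the step.

Within the data shown here, the single step changes the whole group at once, so it leaves open whether the lower number follows from the loss of the carboxy group or from the arrival of the triazole. A plain hydroxymethyl group or a methyl ester on this carbon would separate those two readings, while an amine or a longer chain in place of the hydroxymethyl on the triazole would test how much that end of the group matters.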